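Nitro to amino on compound 1

This account rests on a few compounds, and the source may have more. Where it says the series, first, only, none or still open, it means among the compounds named here.

Values in a functional assay on HT-29 cells (Homo sapiens) for antiproliferative activity, read by MTT assay, with a stated time of 72 h; a higher number here means a weaker inhibitor, a lower number a stronger inhibitor
compound 1 `COc1ccc(-n2ccnc2-c2cc(OC)c(OC)c(OC)c2)cc1[N+](=O)[O-]` gives 600 nM
compound 2 `COc1cc(-c2nccn2-c2ccc(C)cc2)cc(OC)c1OC` gives 1600 nM
compound 3 `COc1cc(-c2nccn2-c2cccc([N+](=O)[O-])c2)cc(OC)c1OC` gives > 100000 nM

For compound 3 this entry is a limit, not a number. Compound 1 at 600 nM has the lower of the two actual numbers, and compound 2 at 1600 nM lies higher, beyond the scatter.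

Compound 4 `COc1ccc(-n2ccnc2-c2cc(OC)c(OC)c(OC)c2)cc1N` has amino in place of nitro on an aromatic carbon, ortho to a methoxy group: amino in place of nitro on an aromatic carbon.

Within the data shown here, no measured step changes the nitro itself. The nearest is an at least 160-fold higher number from compound 1 to compound 3 (2.22 log units; beyond the scatter), a large step that removes the methoxy and ends at the limit of > 100000 nM in this assay, at which 1 of the 3 values shown sits. Compound 4 keeps that methoxy, so no loss of that size is expected. Compound 2 carries no nitro and still gives 1600 nM, so a number in the same range remains plausible.

A moderate estimated step of a 4.0-fold lower number from compound 1 to compound 4 (0.60 log units; beyond the scatter) is expected in this assay, towards a lower number, with little direct support. For compound 4 the expected value is 150 nM, with an estimated range of 20 nM to 1500 nM.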

Compound 4, half-maximal inhibitory concentration: 200 nM
The estimate for compound 4 lay 1.3-fold (0.12 log units) below the measured number; low and high end bracket the measured number.
By their numbers in this assay, from the lowest: compound 4; then compound 1; then compound 2. At a limit, above all of these: compound 3.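

Amino in place of nitro on this aromatic carbon, ortho to a methoxy group, gives a 3.0-fold lower number from compound 1 to compound 4 (0.48 log units; beyond the scatter) in this assay, so the nitro is not required at this position for activity on these cells. Among these compounds, the one earlier step changed the methoxy and left the nitro in place, which makes this the first reading of the group itself. Nothing measured here gives a cause for the step.

The compounds shown leave open whether the lower number is specific to amino or would also appear with a hydroxyl, a methylamino or an acetamide on the same carbon. They also leave open whether amino, like the nitro in the step to compound 3, depends on the methoxy ortho to it.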